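The source may report more compounds than this note shows. Statements on the series, on what has been measured and on what is new or still open speak of the compounds shown alone.

Measured compounds:
- compound 1 `COc1ccccc1Oc1c(N)nc(-c2ccccc2)nc1Cl`: 3140 nM
- compound 2 `COc1ccccc1Oc1c(N)nc(-c2ccc(Cl)cc2)nc1Cl`: 120 nM

In a functional assay on SK-MEL-28 cells (Homo sapiens) for cytotoxicity, read by CCK-8 assay, with a stated time of 24 h (a higher number here means a weaker inhibitor, a lower number a stronger inhibitor), compound 1 gives the highest of the two numbers shown; its nearest neighbour is compound 2, and the step of a 26-fold lower number from compound 1 to compound 2 (1.42 log units; beyond the scatter) is large and well beyond the scatter. That step is chloro in place of hydrogen on an aromatic carbon of the phenyl ring attached to the shared core.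

Compound 3 `COc1ccccc1Oc1c(N)nc(-c2cccc(I)c2)nc1Cl` differs from compound 1 by iodo in place of hydrogen on an aromatic carbon. Going by the values given here, the one measured step that bears on this change is the one from compound 1 to compound 2: it too adds a halogen to the same phenyl ring, though at a different place and with a different halogen. Among the compounds with values here, since a halogen on that ring brought a large drop from compound 1 to compound 2, a drop in this assay is also expected for compound 3, but a more guarded one, as only a single step is available and neither the place nor the halogen matches. The expected step is a 6.3-fold lower number from compound 1 to compound 3 (0.80 log units; beyond the scatter). Compound 3 is estimated at 500 nM, within a range from 120 nM to 2000 nM.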

Compound 3, half-maximal inhibitory concentration: 4660 nM
The estimate for compound 3 lay 9.3-fold (0.97 log units) below the measured number; the measured number lies above the stated range.
By their numbers in this assay, from the lowest: compound 2; then compounds 1 and 3 (each within the scatter of the next).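

In this assay, putting a halogen on this phenyl ring does not by itself bring a lower number. With iodo on an aromatic carbon, meta to a large group, the result is a 1.5-fold higher number from compound 1 to compound 3 (0.17 log units; within the scatter) and compound 3 cannot be told apart from compound 1, while the swap of 4-chlorophenyl for 3-iodophenyl gives a 39-fold higher number from compound 2 to compound 3 (1.59 log units; beyond the scatter) and so removes the large gain seen with compound 2. No measurement available here explains this contrast.

Compound 2 and compound 3 differ in both the halogen and its place on the ring, so these compounds cannot show which of the two matters: the 3-chlorophenyl and 4-iodophenyl groups are the ones that would pull the two apart, since each changes only one of them. From the compounds shown here alone, it also remains open how groups of a different kind would behave on this ring, such as an amine or a carboxylic acid in the place held by the chloro of compound 2, or whether any group at the place held by the iodo of compound 3 can shift the number beyond the scatter.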